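The compounds below may be only part of what the source reports. "The series", "measured", "known", "first", "only" and "open" are said of these compounds alone.

In a functional assay on A549 cells (Homo sapiens) for inhibition, read by MTT assay, with a stated time of 72 h (on this read-out higher numbers stand for weaker inhibition and lower numbers for stronger inhibition), compound 1 `Nc1ncnc2c1c(-c1cnc3[nH]ccc3c1)nn2CCCCCCC(=O)NO` gives 50000 nM, the highest of the two numbers shown in the series. Compound 3 `Nc1nc2cc(-c3nn(CCCCCCCCC(=O)NO)c4ncnc(N)c34)ccc2o1` gives 13200 nM, a lower number than compound 1 by a gap beyond the scatter. Compound 2 `Nc1nc2cc(-c3nn(CCC(=O)NO)c4ncnc(N)c34)ccc2o1` reaches only the limit of the read-out, > 150000 nM. Among the compounds with values here, the one measured step, an at least 11-fold lower number from compound 2 to compound 3 (1.05 log units; beyond the scatter), is the sole paired comparison in the set, and it concerns chain length alone while the end group stays the same. Compound 4 `CNC(=O)CCCCCCCn1nc(-c2cnc3[nH]ccc3c2)c2c(N)ncnc21` differs from compound 1 at the end of the chain: (methylcarbamoyl)methyl in place of hydroxycarbamoyl on a saturated chain carbon, six bonds along the chain from an aromatic nitrogen. Within the data shown here, no measured pair bears on this change; every measured compound keeps the hydroxycarbamoyl end, so the step cannot be read from the set. The series does place one value at the limit of > 150000 nM in this assay, at which 1 of the 3 values shown sits, so a number at the top of the read-out is within reach. The expected step is a 2.4-fold higher number from compound 1 to compound 4 (0.38 log units; beyond the scatter), toward a higher number, of a size judged beyond the scatter. Compound 4 is estimated at 120000 nM, with a range from 40000 nM to 300000 nM.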

Compound 4, half-maximal inhibitory concentration: 51000 nM
The estimate for compound 4 lay 2.4-fold (0.37 log units) above the measured number; the range from low to high includes it.
By their numbers in this assay, from the lowest: compound 3; then compounds 1 and 4 (each within the scatter of the next). At a limit, above all of these: compound 2.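

In this assay the end of the chain now has a measured pair, with a 1.0-fold higher number from compound 1 to compound 4 (0.01 log units; within the scatter) for (methylcarbamoyl)methyl in place of hydroxycarbamoyl. Within the data shown here, at this place, six bonds along the chain from an aromatic nitrogen, the two ends therefore read alike on the core of compound 1, whereas the earlier compounds all kept the hydroxycarbamoyl end and spoke only to chain length. Nothing in the evidence at hand bears on this likeness.

Whether the two ends also read alike on the core of compound 3 stays open, since compound 4 is the only compound shown without the hydroxycarbamoyl end. Going by these compounds, a carboxylic acid or a primary amide at the chain end, and a longer chain on the core of compound 1, also remain open.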